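One More Methoxy Group, Tested Again at Low Concentration

The source may report more compounds than this note shows. Statements on the series, on what has been measured and on what is new or still open speak of the compounds shown alone.

The measurements here come from a functional assay on OVCAR-3 cells (Homo sapiens) for cytotoxicity, read by sulforhodamine B assay, with a stated time of 48 h, tested at 0.01 uM; a lower number here means a stronger effect, a higher number a weaker effect of the compound at the concentration tested. Compound 3, `COc1ccc(-c2cc(/C=C/C(=O)c3ccc(N)cc3)[nH]n2)cc1OC`, gives 106%. Compound 1, `COc1cc(-c2cc(/C=C/C(=O)c3ccc(N)cc3)[nH]n2)cc(OC)c1OC`, differs from compound 3 by methoxy in place of hydrogen on an aromatic carbon. Compound 1 gives 101%; the step is a number 5 percentage points lower from compound 3 to compound 1 (within the scatter). Compound 2, `COc1ccc(C(=O)/C=C/c2cc(-c3cc(OC)c(OC)c(OC)c3)n[nH]2)cc1OC`, gives 100%, and the step is a number 1 percentage points lower from compound 1 to compound 2 (within the scatter). How the core of compound 2 differs from the core of compound 3 is not broken down here. All three numbers show that at this concentration none of the compounds reduced the cell signal in a way that stands out from repeated measurement.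

Compound 4, `COc1cc(C(=O)/C=C/c2cc(-c3cc(OC)c(OC)c(OC)c3)n[nH]2)cc(OC)c1OC`, has not yet been measured. It arises from compound 2 by methoxy in place of hydrogen on an aromatic carbon, and this is the same change that turned compound 3 into compound 1, with the same surroundings at the place of change; it occurs twice among these compounds.

Because a number 5 percentage points lower from compound 3 to compound 1 (within the scatter) stayed within the scatter, the expected step here is no change at the digits printed from compound 2 to compound 4 (within the scatter), that is, no real change. Because 100% already shows essentially no effect for compound 2, compound 4 is expected to give 100% in this assay, with a likely range from 90% to 110%.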

Compound 4, a percentage reported as activity, at one concentration (the size of the read-out at that concentration, not a potency): 107%
Compound 4: the middle estimate sits 7 percentage points below what was measured; the measured number falls inside the stated range.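

In this assay, methoxy in place of hydrogen on an aromatic carbon gives a number 7 percentage points higher from compound 2 to compound 4 (within the scatter). Set beside the earlier case of the same change, the two steps point in opposite directions on paper, yet they do not differ by more than repeated measurement allows: the same change on two cores in this assay, a number 5 percentage points lower (within the scatter) from compound 3 to compound 1 and a number 7 percentage points higher (within the scatter) from compound 2 to compound 4, 12 percentage points apart, within the scatter of two such steps. Within the data shown here, the change therefore carries from one core to the other only in a narrow sense: on both cores it leaves the read-out within the scatter, but this does not show that the methoxy group is without influence on cytotoxicity, as the data come from a single low concentration at which no compound stands out, and a difference appearing only at higher concentrations would not be seen.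

The compounds shown leave open whether a different group at this place, such as an ethoxy group, a fluorine atom or a carboxylic acid, would move the read-out beyond the scatter. They also leave open whether the methoxy step would stay within the scatter on other cores, or at a concentration where these compounds clearly reduce the cell signal.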